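From benzoyloxy to hydroxy on the shared core

The source may hold more compounds than are shown below. What is called first, only, known or untested is meant among the compounds shown, and "the series" means these compounds.

In an ADME assay on MT4 cells (Homo sapiens) for cytotoxicity, read by MTT assay, with a stated time of 96 h (a lower number here means that less compound is tolerated, a higher number that more compound is tolerated), compound 1 (`O=C(Oc1ccc2ccc(=O)oc2c1CN1CCc2ccccc2C1)c1ccccc1`) gives > 100000 nM as a limit and not a number. Compound 2 (`Cc1cc(=O)oc2c(CN3CCc4ccccc4C3)c(OC(=O)c3ccccc3)ccc12`) gives > 100000 nM as a limit too. Compound 3 (`COc1ccc2c(=O)c(Cc3c(OC(C)=O)ccc4ccc(=O)oc34)c(N3CCCC3)oc2c1`) likewise gives > 100000 nM as a limit. The data so far amount to a single ceiling (the limit of > 100000 nM in this assay, at which 3 of the 3 values shown sit) and compound 1 therefore offers no number to start from.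

Compound 4 (`O=c1ccc2ccc(O)c(CN3CCc4ccccc4C3)c2o1`) differs from compound 1 by one change (hydrogen in place of benzoyl on an oxygen on an aromatic ring) that reads as benzoyloxy to hydroxy. Among the compounds with values here, the only measured step (a step that the two limits leave unreadable from compound 1 to compound 2) is a different change, methyl in place of hydrogen on an aromatic carbon, and it has no size to lend. Within the data shown here, no measured compound carries the hydroxy of compound 4. The expectation therefore rests on the structural change alone. A modest move in this assay toward less compound tolerated is allowed for, while a further reading at the ceiling remains quite possible. The estimated step (an at least 1.4-fold lower number from compound 1 to compound 4 (0.15 log units; that floor lies within the scatter)) is accordingly downward and only loosely bounded. For compound 4 the expected value is 70000 nM with an estimated range (20000 nM to 100000 nM).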

Compound 4, half-maximal cytotoxic concentration: > 100000 nM
Compound 4: no number, only a limit; the forecaster's own chance of this, stated with the estimate: 50%; at least 1.4-fold (0.15 log units) between middle value and limit.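

Compound 1 and compound 4 are both reported only as limits in this assay, so the step between them cannot be read and no new step follows: the limit of > 100000 nM in this assay, at which 4 of the 4 values shown sit.

The compounds shown leave open whether benzoyloxy and hydroxy differ at all in this assay, and at what concentration any compound of the series becomes cytotoxic.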